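Methoxy to hydroxy on compound 2: expected growth inhibition

A few compounds are considered here, and "the series" means these few. Any claim that something is new, unique, unknown or untested is made for them only; others in the source may bear on it.

Measured so far, in a functional assay on MDA-MB-468 cells (Homo sapiens) for inhibition, read by sulforhodamine B assay, with a stated time of 48 h; a higher number here means a weaker inhibitor of growth, a lower number a stronger inhibitor of growth:
Compound 1, `O=C(Nc1cccc(-n2cc(-c3ccncc3)c(-c3ccc(Cl)c(O)c3)n2)c1)Nc1cccc(C(F)(F)F)c1`, gives 7830 nM.
Compound 2, `COc1cc(-c2nn(-c3cccc(NC(=O)Nc4cc(C(F)(F)F)cc(C(F)(F)F)c4)c3)cc2-c2ccncc2)ccc1Cl`, gives 1540 nM.
Compound 3, `COc1cc(-c2nn(-c3cccc(NC(=O)Nc4cccc(C(F)(F)F)c4)c3)cc2-c2ccncc2)ccc1Cl`, gives 2160 nM.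

Compound 2 has the lowest of the three numbers. Its nearest neighbour is compound 3, and the gap between them, a 1.4-fold higher number from compound 2 to compound 3 (0.15 log units; within the scatter), is within the scatter, so the two cannot be ordered. Compound 1 stands further off; compound 1 and compound 2 differ in two places at once, so only the two values themselves can be set side by side.

Compound 4, `O=C(Nc1cccc(-n2cc(-c3ccncc3)c(-c3ccc(Cl)c(O)c3)n2)c1)Nc1cc(C(F)(F)F)cc(C(F)(F)F)c1`, is not yet measured. It differs from compound 2 by hydrogen in place of methyl on an oxygen on an aromatic ring. Among the measured compounds shown here, the one measured step that bears on this runs the opposite way, from hydroxy to methoxy: a 3.6-fold lower number from compound 1 to compound 3 (0.56 log units; beyond the scatter). Reversed, it suggests that taking the methyl off the oxygen should raise the number by a modest amount, in the same region as that step. The other step, a 1.4-fold higher number from compound 2 to compound 3 (0.15 log units; within the scatter), concerns a different site and adds nothing here beyond showing that the two trifluoromethyl patterns give numbers within the scatter of each other.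

Compound 4 is therefore expected to give about 5500 nM in this assay, with a range of 2500 nM to 12000 nM. The step expected is a 3.6-fold higher number from compound 2 to compound 4 (0.55 log units; beyond the scatter), a weakening of growth inhibition.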

Compound 4, concentration for total growth inhibition: 2660 nM
Compound 4: middle estimate off by 2.1-fold (0.32 log units), on the high side; measured number inside the range.
By their numbers in this assay, from the lowest: compounds 2, 3 and 4 (each within the scatter of the next); then compound 1.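

In this assay, methoxy to hydroxy on the core of compound 2, which carries two trifluoromethyl groups, gives a 1.7-fold higher number from compound 2 to compound 4 (0.24 log units; within the scatter), so here the two compounds cannot be ordered, and this change is not shown to cost growth inhibition on every core; even so, its size cannot be said to depend on the core: the same change on two cores in this assay, a 3.6-fold lower number (0.56 log units; beyond the scatter) from compound 1 to compound 3 and a 1.7-fold lower number (0.24 log units; within the scatter) from compound 4 to compound 2, 2.1-fold (0.32 log units) apart, within the scatter of two such steps

The second trifluoromethyl, whose effect could not be read with methoxy at this position, has a readable effect with hydroxy, as a 2.9-fold lower number from compound 1 to compound 4 (0.47 log units; beyond the scatter) shows; again, the difference between cores remains unresolved: the same change on two cores in this assay, a 1.4-fold higher number (0.15 log units; within the scatter) from compound 2 to compound 3 and a 2.9-fold higher number (0.47 log units; beyond the scatter) from compound 4 to compound 1, 2.1-fold (0.32 log units) apart, within the scatter of two such steps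

Taken together, compound 1 is the only one of the four set apart from the others by a step beyond the scatter, and hydroxy with a single trifluoromethyl is the only combination that stands out.

Going by these compounds, whether this oxygen accepts an ethyl group, a longer chain or a carboxylic acid in place of hydrogen or methyl remains open. So does the result of replacing the hydroxy with an amine, on either trifluoromethyl pattern.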